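A Small Aromatic Swap: From Compound 1 to Compound 4

The compounds below may be only part of what the source reports. "The series", "measured", "known", "first", "only" and "open" are said of these compounds alone.

Of the compounds shown here, three have so far been measured in a functional assay on MCF7 cells (Homo sapiens) for cytotoxicity, read by MTT assay, with a stated time of 72 h; a lower number here means a stronger inhibitor of growth, a higher number a weaker inhibitor of growth. Compound 1 `COc1ccc(OC(=O)Nc2ccc([Se]C#N)cc2)cc1` gives 48200 nM. Compound 2 `CCCOC(=O)Nc1ccc([Se]C#N)cc1` gives 34400 nM, and compound 3 `CCCCOC(=O)Nc1ccc([Se][Se]c2ccc(NC(=O)OCCCC)cc2)cc1` gives 46300 nM. All three numbers lie within the usual scatter of one another: compound 1 is not separated from compound 3, nor from compound 2, by more than repeated measurements of this kind would show, so none of the three can be ranked against the others on these numbers alone.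

Compound 4 `Cc1ccc(OC(=O)Nc2ccc([Se]C#N)cc2)cc1` has not yet been measured. It differs from compound 1 by methyl in place of methoxy on an aromatic carbon. Among the measured compounds shown here, no two of the measured compounds differ from each other in just one place, so there is no directly comparable step to lean on. What the measured numbers do show is that three rather different compounds all fall in the same narrow band in this assay, and the change from compound 1 to compound 4 is a small one. The step from compound 1 to compound 4 is therefore expected to be a 1.1-fold lower number from compound 1 to compound 4 (0.03 log units; within the scatter), that is, nothing beyond the scatter in either direction. Compound 4 is expected to give about 45000 nM, with a plausible range from 20000 nM to 100000 nM.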

Compound 4, concentration for total growth inhibition: 39900 nM
For compound 4 the middle estimate is 1.1-fold (0.05 log units) above the measured one; the range from low to high includes it.
By their numbers in this assay, from the lowest: compounds 2, 4, 3 and 1 (each within the scatter of the next).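

Among the compounds shown here, the pair gives the set its first comparison in which only one place changes: in this assay, methyl in place of methoxy on an aromatic carbon, para to a large group, gives a 1.2-fold lower number from compound 1 to compound 4 (0.08 log units; within the scatter), which lies within the scatter. Methoxy carries an oxygen counted as a hydrogen-bond acceptor and methyl carries none, yet this read-out does not separate the two compounds, so at this position, for this one change, the assay gives no sign that the oxygen matters. No independent measurement is available to explain why compound 1 and compound 4 read alike.

The compounds shown leave open whether this position responds at all, since only methoxy and methyl have been compared here, and a group of another kind at the same place, such as an amine, a carboxylic acid or a longer chain, might or might not give a step beyond the scatter. They also leave open whether methyl in place of methoxy would read the same way on a different core.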